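The source may report more compounds than this note shows. Statements on the series, on what has been measured and on what is new or still open speak of the compounds shown alone.

Working notes on the series, read in a functional assay on C8166 cells (Homo sapiens) for cytotoxicity, read by MTT assay; a higher number here means that more compound is tolerated, a lower number that less compound is tolerated. Compound 1 `Cc1cccc(C(=O)Nc2cc(Cl)ccc2OCC(=O)Nc2ccc(S(N)(=O)=O)cc2C)c1` gives 52900 nM, compound 2 `Cc1cc(S(N)(=O)=O)ccc1NC(=O)COc1ccc(Cl)cc1NC(=O)c1cccc(Cl)c1` gives 59700 nM, and compound 3 `COc1ccc(C(=O)Nc2cc(Cl)ccc2OCC(=O)Nc2ccc(S(N)(=O)=O)cc2C)cc1` gives 69500 nM. Compound 2 therefore stands within the scatter of both other compounds, and the three numbers cannot be separated.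

The unmeasured structure is compound 4 `Cc1ccc(C)c(C(=O)Nc2cc(Cl)ccc2OCC(=O)Nc2ccc(S(N)(=O)=O)cc2C)c1`. It differs from compound 2 by 2,5-dimethylphenyl in place of 3-chlorophenyl on a carbonyl carbon.

Two measured exchanges at this same carbonyl carbon bear most directly on the change: a 1.2-fold higher number from compound 2 to compound 3 (0.07 log units; within the scatter) and a 1.3-fold higher number from compound 1 to compound 3 (0.12 log units; within the scatter). The exchange of chloro for methyl on an aromatic carbon also bears on it: a 1.1-fold higher number from compound 1 to compound 2 (0.05 log units; within the scatter). All of these steps lie within the scatter. Within the data shown here, no measured compound carries the 2,5-dimethylphenyl group, so the data give no direct reading for it.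

No step beyond the scatter is expected in this assay, and neither direction is favoured. The estimated step is a 1.0-fold lower number from compound 2 to compound 4 (0.01 log units; within the scatter). For compound 4 the expected value is 58000 nM, with an estimated range of 30000 nM to 110000 nM.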

Compound 4, half-maximal cytotoxic concentration: 79700 nM
Compound 4: the middle estimate sits 1.4-fold (0.14 log units) below what was measured; the range from low to high includes it.
By their numbers in this assay, from the lowest: compounds 1, 2, 3 and 4 (each within the scatter of the next).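

In this assay the step to 2,5-dimethylphenyl on this carbonyl carbon reads as a 1.3-fold higher number from compound 2 to compound 4 (0.13 log units; within the scatter) against 3-chlorophenyl and as a 1.1-fold higher number from compound 3 to compound 4 (0.06 log units; within the scatter) against 4-methoxyphenyl, so a dimethyl-substituted phenyl also stays within the scatter of the other aryl groups at this position. Methyl in place of hydrogen on an aromatic carbon, which turns the 3-methylphenyl group into the 2,5-dimethylphenyl group, gives a 1.5-fold higher number from compound 1 to compound 4 (0.18 log units; within the scatter) and likewise does not separate the two compounds, so all three new steps leave this carbonyl position without a measurable trend in tolerated concentration. No measured information on the compounds accounts for these numbers, and no cause can be assigned to any of the steps.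

Every group shown at this carbonyl carbon is a substituted phenyl without charge, so it remains open whether a cyclohexyl group, or a carboxylic acid or an aminomethyl group on the phenyl ring, would give a step beyond the scatter. Changes elsewhere in the shared core, such as at the sulfonamide or at the chloro group, also remain open.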